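From allyl to benzyl: a small step expected

This account rests on a few compounds, and the source may have more. Where it says the series, first, only, none or still open, it means among the compounds named here.

Measured in a functional assay on U-937 cells (Homo sapiens) for cytotoxicity, read by MTT assay, with a stated time of 24 h; a lower number here means a stronger inhibitor, a higher number a weaker inhibitor:
- compound 1 `BrCCCCCCOc1c(Br)cc(Br)cc1Oc1ccc(Br)cc1Br`: 33.8 ug/mL
- compound 2 `CCOC(=O)C(C)Oc1c(Br)cc(Br)cc1Oc1ccc(Br)cc1Br`: 39.5 ug/mL
- compound 3 `C=CCOc1c(Br)cc(Br)cc1Oc1ccc(Br)cc1Br`: 29 ug/mL

In this assay, compound 3 gives 29 ug/mL, which lies within the scatter of the other two values. The next compound, compound 4 `Brc1ccc(Oc2cc(Br)cc(Br)c2OCc2ccccc2)c(Br)c1`, differs from it as follows: phenyl in place of vinyl on a saturated chain carbon bound to an oxygen on an aromatic ring. In words, allyl becomes benzyl, with phenyl in place of vinyl on a saturated chain carbon bound to an oxygen on an aromatic ring. For the measured compounds named here, three measured steps bear on this change: a 1.2-fold higher number from compound 1 to compound 2 (0.07 log units; within the scatter), a 1.2-fold lower number from compound 1 to compound 3 (0.07 log units; within the scatter) and a 1.4-fold lower number from compound 2 to compound 3 (0.13 log units; within the scatter). From the compounds shown here alone, all are small, but none introduces a phenyl, so this exact change remains untested. No step beyond the scatter is therefore expected in this assay. The estimated step is a 1.0-fold higher number from compound 3 to compound 4 (0.01 log units; within the scatter). Compound 4 is expected at 30 ug/mL, with an estimated range of 18 ug/mL to 50 ug/mL.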

Compound 4, half-maximal inhibitory concentration: 29 ug/mL
Compound 4: middle estimate off by 1.0-fold (0.01 log units), on the high side, within the range that was stated.
By their numbers in this assay, from the lowest: compounds 3, 4, 1 and 2 (each within the scatter of the next).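

In this assay, phenyl in place of vinyl gives no change at the digits printed from compound 3 to compound 4 (within the scatter) and adds the first aromatic ring at this place, so a ring here causes no step beyond the scatter. Both a 1.4-fold lower number from compound 2 to compound 4 (0.13 log units; within the scatter) and a 1.2-fold lower number from compound 1 to compound 4 (0.07 log units; within the scatter) are small as well, so benzyl reads like the ester and 6-bromohexyl groups. Nothing measured here explains why these different groups read alike. From the compounds shown here alone, whether an amine or a carboxylic acid on this oxygen would give a step beyond the scatter stays open.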